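This account rests on a few compounds, and the source may have more. Where it says the series, first, only, none or still open, it means among the compounds named here.

Compound 1 `O=S(=O)(/C=C/c1ccccn1)c1ccccc1Cl` stands second highest of the three numbers in an assay on U2OS cells for activation of nuclear factor erythroid 2-related factor 2 (Homo sapiens), read by beta-arrestin recruitment, with a stated time of 6 h (on this read-out lower numbers stand for an effect already at smaller amounts and higher numbers for an effect only at larger amounts of compound), where compound 1 gives 618 nM. Compound 2 `O=S(=O)(/C=C/c1ncccc1Cl)c1ccccc1Cl` gives 26 nM and compound 3 `O=S(=O)(/C=C/c1ccc(Cl)cn1)c1ccccc1Cl` gives 2940 nM; the two steps, a 24-fold lower number from compound 1 to compound 2 (1.38 log units; beyond the scatter) and a 4.8-fold higher number from compound 1 to compound 3 (0.68 log units; beyond the scatter), each put a chloro in place of hydrogen on an aromatic carbon, pulling in opposite directions. Compound 4 `O=S(=O)(/C=C/c1cccnc1)c1ccccc1Cl` differs from compound 1 in another way: pyridin-3-yl in place of pyridin-2-yl on a double-bonded chain carbon bound to a double-bonded chain carbon. Neither measured step touches the pyridin-2-yl itself, so neither bears directly on this change, and the data give no guide to its direction. For compound 4 the expected step of a 1.1-fold higher number from compound 1 to compound 4 (0.05 log units; within the scatter) is therefore none beyond the scatter, with a wide range. Compound 4 is estimated at 700 nM, between 150 nM and 3500 nM.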

Compound 4, half-maximal effective concentration: 2850 nM
Estimate against measurement, compound 4: 4.1-fold (0.61 log units) below; low and high end bracket the measured number.
By their numbers in this assay, from the lowest: compound 2; then compound 1; then compounds 4 and 3 (each within the scatter of the next).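

Swapping in pyridin-3-yl for pyridin-2-yl gives a 4.6-fold higher number from compound 1 to compound 4 (0.66 log units; beyond the scatter) in this assay. The atoms and the counted hydrogen-bond acceptors stay the same, so how the ring is joined to the chain alone separates these two compounds on this read-out. Nothing available accounts for this shift.

Open, going by these compounds, is how a pyridin-4-yl group or a plain phenyl group would read at this place. Also open, on these data alone, is whether a chloro on the pyridin-3-yl of compound 4 would lower or raise the number.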